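One hydroxy group added to compound 1

The source may report more compounds than this note shows. Statements on the series, on what has been measured and on what is new or still open speak of the compounds shown alone.

Among the compounds with values here, in a functional assay on HL-60 cells (Homo sapiens) for cytotoxicity, read by WST assay, with a stated time of 48 h (a higher number here means that more compound is needed for the effect, a lower number that less compound is needed), compound 1 (`Clc1ccc(C[C@H]2COC[C@@H]2Cc2ccccc2)cc1Cl`) gives 19000 nM and holds the second highest of the three numbers so far. Compound 2 (`CCCCOc1ccccc1C[C@H]1COC(=O)[C@@H]1Cc1ccc(Cl)c(Cl)c1`) gives 10000 nM and compound 3 (`COc1ccc(C[C@H]2COC(=O)[C@@H]2Cc2ccc(Cl)c(Cl)c2)cc1O`) gives 32000 nM in the same test. Both lie within the usual scatter of compound 1, so neither can be ranked against it.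

Compound 4 (`Oc1ccc(C[C@H]2COC[C@@H]2Cc2ccc(Cl)c(Cl)c2)cc1`) carries one change from compound 1: phenyl becomes 4-hydroxyphenyl, with hydroxy in place of hydrogen on an aromatic carbon. Within the data shown here, no pair of measured compounds shows this change alone, so any forecast is indirect. Compound 3 also carries a hydroxy group on an aromatic ring, though it differs in other ways, and at 32000 nM it stays within the scatter of compound 1. No step beyond the scatter is therefore expected in this assay for this change. The estimated step is small, a 1.3-fold lower number from compound 1 to compound 4 (0.10 log units; within the scatter) and no more. Compound 4 is expected to give about 15000 nM with a likely range from 6000 nM to 40000 nM once it is measured.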

Compound 4, half-maximal effective concentration: 31000 nM
Compound 4: the middle estimate sits 2.1-fold (0.32 log units) below what was measured, within the range that was stated.
By their numbers in this assay, from the lowest: compounds 2, 1, 4 and 3 (each within the scatter of the next, the first and the last beyond it).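

In this assay, within the data shown here, the pair gives a 1.6-fold higher number from compound 1 to compound 4 (0.21 log units; within the scatter) for hydroxy in place of hydrogen on an aromatic carbon, para to a large group, and this is the first reading of that change on its own. The step lies within the scatter, so compound 4 and compound 1 cannot be ranked, and the added hydroxy group at this position produces no shift that can be told apart from repeat-to-repeat variation. A single pair, however, speaks only for this one position on this one core.

As far as these compounds go, whether an amine or a carboxylic acid in the same place would move the number beyond the scatter stays open, as does the effect of a hydroxy group elsewhere on the ring. No measurement shown here offers an explanation for the size of this step.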